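The source may report more compounds than this note shows. Statements on the series, on what has been measured and on what is new or still open speak of the compounds shown alone.

Working notes on the series, read in a physicochemical assay for solubility; on this read-out higher numbers stand for higher solubility and lower numbers for lower solubility. Compound 1 `CNC(=O)c1cc(C(=O)NC2CCOCC2)cn(Cc2ccccc2)c1=O` reads >= 174 ug/mL, which is a limit of the assay and not a number. For the measured compounds named here, compound 2 `CNC(=O)c1cc(C(=O)NCC(C)C)cn(Cc2ccccc2)c1=O` gives 43 ug/mL, the only true number so far.

Compound 3 `CNC(=O)c1cc(C(N)=O)cn(Cc2ccccc2)c1=O` is derived from compound 2 by hydrogen in place of isobutyl on an amide-type nitrogen.

Going by the values given here, one measured step bears on this change: an at least 4.0-fold lower number from compound 1 to compound 2 (0.60 log units; beyond the scatter), which lies beyond the scatter. In that step isobutyl took the place of oxan-4-yl on the same amide-type nitrogen, and the number fell. Here isobutyl leaves instead, so a rise of modest size is expected in this assay. The support is thin, as the group entering here is hydrogen rather than oxan-4-yl, and a single step sets the direction.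

The estimated change is a 2.6-fold higher number from compound 2 to compound 3 (0.41 log units; beyond the scatter). Compound 3 is expected at 110 ug/mL, with an estimated range of 40 ug/mL to 300 ug/mL.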

Compound 3, solubility: 71 ug/mL
For compound 3 the middle estimate is 1.5-fold (0.19 log units) above the measured one; the range from low to high includes it.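

Hydrogen in place of isobutyl on the amide-type nitrogen gives a 1.7-fold higher number from compound 2 to compound 3 (0.22 log units; within the scatter), so in this assay the isobutyl chain and the bare carbamoyl cannot be told apart at this position. Hydrogen in place of oxan-4-yl on the same nitrogen gives an at least 2.4-fold lower number from compound 1 to compound 3 (0.38 log units; beyond the scatter), so the earlier drop on moving away from oxan-4-yl now appears with two different replacements, isobutyl and hydrogen, and oxan-4-yl stands apart from both in this small set. Compound 1 reads >= 174 ug/mL, which is a limit of the assay and not a number, so each step out of it gives only a minimum size and the full gap stays unknown: the limit of >= 174 ug/mL in this assay, at which 1 of the 3 values shown sits.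

Open, from the compounds shown here alone, is whether a cyclohexyl group on this nitrogen would read with compound 1 or with compound 2 and compound 3, which would separate the ring itself from its oxygen, and where a piperidin-4-yl amine or a longer chain would fall. Going by these compounds, every change shown sits on this one amide-type nitrogen, so how the read-out responds to replacing the benzyl group or the methylamide also stays open.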